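Swapping the benzofuranoyl cap for a dienoyl cap

The source may report more compounds than this note shows. Statements on the series, on what has been measured and on what is new or still open speak of the compounds shown alone.

Within the data shown here, compound 2 `CCCCCCCCCCCCCCCCCCNC(=O)[C@@H](NC(=O)c1cc2ccccc2o1)[C@@H](C)O` gives 78800 nM in a functional assay on A-431 cells (Homo sapiens) for cytotoxicity, read by MTT assay, with a stated time of 48 h (a lower number here means a stronger inhibitor, a higher number a weaker inhibitor), and holds the only numerical value shown there. Compound 1 `C/C=C/C=C/C(=O)N[C@H](C(=O)NCCCCCCCCCCCCCC)[C@@H](C)O` reaches only the limit of this assay, > 200000 nM. Compound 3 `C/C=C/C=C/C(=O)N[C@H](C(=O)NCCCCCCCCCCCCCCCCCC)[C@@H](C)O` is not yet measured; it carries penta-1,3-dien-1-yl in place of 1-benzofuran-2-yl on a carbonyl carbon on the octadecyl amide of compound 2. Among the measured compounds shown here, no step between measured compounds that differ in one place is available. Compound 1, bearing the same penta-1,3-dien-1-yl carbonyl, supports (the limit of > 200000 nM in this assay, at which 1 of the 2 values shown sits). Compound 3 is therefore expected to weaken, an estimated step of a 2.5-fold higher number from compound 2 to compound 3 (0.40 log units; beyond the scatter). Compound 3 is estimated at 200000 nM, within 70000 nM to 500000 nM.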

Compound 3, half-maximal inhibitory concentration: 187000 nM
For compound 3 the middle estimate is 1.1-fold (0.03 log units) above the measured one, within the range that was stated.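

In this assay, with the octadecyl amide held fixed, penta-1,3-dien-1-yl in place of 1-benzofuran-2-yl on the carbonyl carbon gives a 2.4-fold higher number from compound 2 to compound 3 (0.38 log units; beyond the scatter), so this position now has a change with a number at both ends. Butyl in place of hydrogen on the saturated chain gives an at least 1.0-fold lower number from compound 1 to compound 3 (0.02 log units; that floor lies within the scatter), so the size of that chain step cannot be read. Compound 1 stands only as a limit of the assay: the limit of > 200000 nM in this assay, at which 1 of the 3 values shown sits.

Open, as far as these compounds go, are a cap carrying an amine or a carboxylic acid and a chain longer than octadecyl.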